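The source may hold more compounds than are shown below. What is called first, only, known or untested is meant among the compounds shown, and "the series" means these compounds.

Compound 1 `C=C1CC[C@@H]2[C@](C)(CCC[C@]2(C)C(=O)O)[C@H]1CC/C(C)=C/CO` is the starting point. In a functional assay on HL-60 cells (Homo sapiens) for cytotoxicity, read by MTT assay, with a stated time of 48 h (a lower number here means a stronger inhibitor, a higher number a weaker inhibitor), compound 1 returns only a limit of the assay, > 40000 nM. Where compound 1 stands is thus given by the limit of > 40000 nM in this assay, at which 1 of the 2 values shown sits, not by a number. The other measured compound, compound 2 `C=CC(=C)CC[C@@H]1[C@@]2(C)CCC[C@](C)(COC(=O)/C=C/c3ccc(O)c(OC)c3)[C@@H]2CC[C@@]1(C)O`, gives 14300 nM in this assay. Compound 3 `C=C[C@@](C)(O)CC[C@H]1C(=C)CC[C@@H]2[C@]1(C)CCC[C@]2(C)C(=O)O` carries the change (1-hydroxy-1-methylprop-2-en-1-yl in place of 3-hydroxy-1-methylprop-1-en-1-yl on a saturated chain carbon, two bonds along the chain from a saturated ring carbon), the same atoms joined differently. Among the compounds with values here, no measured step of this kind exists, so the step from compound 1 to compound 3 is expected to be about none beyond the scatter, a step that the limit leaves unreadable from compound 1 to compound 3. Compound 3 is therefore estimated at 45000 nM, within 15000 nM to 150000 nM, most likely again reported as a limit.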

Compound 3, half-maximal inhibitory concentration: > 40000 nM
Compound 3: only a limit was reported; the forecaster's own chance of this, stated with the estimate: 70%; the middle value does not contradict the limit.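

No step can be read from compound 1 to compound 3, because both stand only at a limit: the limit of > 40000 nM in this assay, at which 2 of the 3 values shown sit. The compounds shown leave open whether 1-hydroxy-1-methylprop-2-en-1-yl in place of 3-hydroxy-1-methylprop-1-en-1-yl changes the reading in this assay at all.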